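The source may report more compounds than this note shows. Statements on the series, on what has been measured and on what is new or still open speak of the compounds shown alone.

Measured so far:
- compound 1 `O=C(Nc1cccc([N+](=O)[O-])c1)N[C@H]1CC[C@H](Oc2ccc(F)cc2)CC1`: 6700 nM
- compound 2 `O=C(Nc1cccc(C(F)(F)F)c1)N[C@H]1CC[C@H](Oc2cccc(F)c2)CC1`: 2400 nM
- compound 3 `O=C(Nc1cccc(C(F)(F)F)c1)N[C@H]1CC[C@H](Oc2ccc(Cl)cc2)CC1`: 2000 nM

All three numbers come from a functional assay on CRL2813 cells (Homo sapiens) for cytotoxicity, read by sulforhodamine B assay, with a stated time of 5 days; a lower number here means a stronger inhibitor, a higher number a weaker inhibitor. Compound 3 stands at the low end of the three, but its gap to compound 2 is within the scatter, so the two cannot be ordered; only compound 1 sits clearly apart, with a number beyond the scatter above that of compound 3. Within the data shown here, compound 1 also differs from compound 3 in two places, so no single step can be drawn from it.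

The next compound is compound 4 `O=C(Nc1cccc(C(F)(F)F)c1)N[C@H]1CC[C@H](Oc2ccccc2F)CC1`. The change from compound 3:
2-fluorophenyl in place of 4-chlorophenyl on an oxygen on a saturated carbon

Among the measured compounds shown here, only one measured step bears on this position: a 1.2-fold lower number from compound 2 to compound 3 (0.08 log units; within the scatter). That swap, also of one halogenated phenyl for another on the oxygen, moved the number by an amount within the scatter. The present change again exchanges one halogenated phenyl for another at the same place, so nothing in the measured steps argues for a movement beyond the scatter in this assay, in either direction.

Compound 4 is therefore expected to stay close to compound 3, with the step of a 1.3-fold higher number from compound 3 to compound 4 (0.11 log units; within the scatter) estimated to lie within the scatter. The estimate for compound 4 is 2600 nM, with a range from 1300 nM to 5500 nM.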

Compound 4, half-maximal inhibitory concentration: 2450 nM
Compound 4: the middle estimate sits 1.1-fold (0.03 log units) above what was measured; measured number inside the range.
By their numbers in this assay, from the lowest: compounds 3, 2 and 4 (each within the scatter of the next); then compound 1.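

In this assay, 2-fluorophenyl in place of 4-chlorophenyl on the oxygen gives a 1.2-fold higher number from compound 3 to compound 4 (0.09 log units; within the scatter), so a third halogenated phenyl at this place falls within the scatter of the other two, and the earlier single step is no longer an isolated reading. Among these compounds, the pair sharing a fluorine adds a comparison the earlier compounds did not offer: with the halogen kept and only its ring position altered, 2-fluorophenyl in place of 3-fluorophenyl gives a 1.0-fold higher number from compound 2 to compound 4 (0.01 log units; within the scatter), so these two fluorophenyl isomers cannot be told apart in this cytotoxicity read-out. No other measurement is available to interpret this flat response.

All the groups shown at this place on the oxygen are halogenated phenyls, so it remains open whether the number would hold for a phenyl bearing an amine or a carboxylic acid, or for a saturated chain in place of the aromatic ring. The contribution of the nitro group of compound 1 also stays unresolved, since compound 1 differs from the other compounds in more than one place.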